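The compounds below may be only part of what the source reports. "The series", "measured", "known", "first", "only" and "open" are said of these compounds alone.

Measured compounds:
- compound 1, `CN1CCN(c2ccc(C3=NN(C(=O)CCCl)C(c4ccc(N(C)C)cc4)C3)cc2)CC1`: 1.7%
- compound 2, `Cc1ccc(S(=O)(=O)N2N=C(c3ccc(N4CCN(C)CC4)cc3)CC2c2ccc(N(C)C)cc2)cc1`: 32.2%

In a functional assay on HCC1806 cells (Homo sapiens) for inhibition, read by sulforhodamine B assay, tested at 10 uM (a lower number here means less inhibition, a higher number more inhibition at the concentration tested (going by the name of the read-out)), compound 2 gives the higher of the two numbers, and the step of a number 30.5 percentage points higher from compound 1 to compound 2 (beyond the scatter) lies beyond the scatter. Compound 3, `CN1CCN(c2ccc(C3=NN(S(=O)(=O)c4ccc(Br)cc4)C(c4ccc(N(C)C)cc4)C3)cc2)CC1`, is not yet measured. It differs from compound 2 by bromo in place of methyl on an aromatic carbon. Going by the values given here, no measured step changes this part of the shared core, since the one known step swaps the whole group on the ring nitrogen, so nothing here speaks for a shift in this assay beyond the scatter. Compound 3 is therefore expected to give about 32%, between 15% and 50%, a step of a number 0.2 percentage points lower from compound 2 to compound 3 (within the scatter) that is estimated to stay within the scatter.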

Compound 3, a percentage reported as inhibition, at one concentration (the size of the read-out at that concentration, not a potency): 87.1%
Estimate against measurement, compound 3: 55.1 percentage points below, and the stated range ends below it.
By their numbers in this assay, from the lowest: compound 1; then compound 2; then compound 3.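

The methyl-to-bromo swap on the 4-methylphenyl ring changes only one heavy atom, yet in this assay it gives a large change (a number 54.9 percentage points higher from compound 2 to compound 3 (beyond the scatter)). So this outer position of the sulfonyl group matters, and the sulfonyl alone does not set the number: replacing the (2-chloroethyl)carbonyl group gives a number 30.5 percentage points higher from compound 1 to compound 2 (beyond the scatter) with the 4-methylphenyl version but a number 85.4 percentage points higher from compound 1 to compound 3 (beyond the scatter) with the 4-bromophenyl version. Nothing available explains why bromo has this effect. On these data alone, whether chloro, methoxy or an amine at this place would behave like bromo remains open.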